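Ester for tert-Butyl on the Weak Phenyl Analogue

This account rests on a few compounds, and the source may have more. Where it says the series, first, only, none or still open, it means among the compounds named here.

Measured compounds in a functional assay on MCF7 cells (Homo sapiens) for inhibition, read by CCK-8 assay, with a stated time of 48 h; on this read-out lower numbers stand for stronger inhibition and higher numbers for weaker inhibition:
Compound 1 `COc1cc(-c2ccnc3cc(-c4ccc5cc[nH]c5c4)nn23)cc(OC)c1OC` gives 23 nM.
Compound 3 `COc1cc(-c2ccnc3cc(-c4c[nH]c5ccccc45)nn23)cc(OC)c1OC` gives 85 nM.
Compound 2 `COc1cc(-c2ccnc3cc(-c4ccc(C(C)(C)C)cc4)nn23)cc(OC)c1OC` gives only the limit > 10000 nM, not a number.

The three compounds share one core and differ only in the aromatic group attached to it. Compound 2 stands at the bottom of the set, at the assay limit (the limit of > 10000 nM in this assay, at which 1 of the 3 values shown sits), and its steps to both other compounds are large: an at least 430-fold higher number from compound 1 to compound 2 (2.63 log units; beyond the scatter) and an at least 110-fold lower number from compound 2 to compound 3 (2.07 log units; beyond the scatter). Each of those steps swaps the whole 4-(tert-butyl)phenyl group for an indolyl group, with the ring attached to the same aromatic carbon of the core.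

The unmeasured compound 4 `CCOC(=O)c1ccc(-c2cc3nccc(-c4cc(OC)c(OC)c(OC)c4)n3n2)cc1` keeps the phenyl ring and changes only its substituent: ethoxycarbonyl in place of tert-butyl on an aromatic carbon. Within the data shown here, no measured step tests a swap of this kind; the measured steps tell only that the compound with a para-substituted phenyl is the weak one, while the two indolyl compounds are strong. On that basis compound 4 is expected to stay weak, with an estimated 8000 nM in this assay, in a range from 2000 nM to 30000 nM. The step of an at least 1.2-fold lower number from compound 2 to compound 4 (0.09 log units; that floor lies within the scatter) is expected to be small relative to the scatter, and a limit reading for compound 4 is about as likely as a number.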

Compound 4, half-maximal inhibitory concentration: > 10000 nM
Compound 4 was reported as a limit; the forecaster's own chance of this, stated with the estimate: 50%; middle value at least 1.2-fold (0.09 log units) from the limit.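

Compound 2 and compound 4 each give a limit rather than a number, so no step between them can be read: the limit of > 10000 nM in this assay, at which 2 of the 4 values shown sit.

The compounds shown leave open how far each lies beyond that limit, and so whether ethoxycarbonyl in place of tert-butyl changes the inhibition at all.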